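The compounds below may be only part of what the source reports. "The series", "measured", "known", "first", "only" and "open" are said of these compounds alone.

Measured so far:
compound 1 `CCN1C(=O)C2(C(C#N)=C(N)Oc3cc4oc(-c5ccccc5)cc(=O)c4c(O)c32)c2cccc(C)c21` — > 50000 nM
compound 2 `CCN1C(=O)C2(C(C#N)=C(N)Oc3cc4oc(-c5ccccc5)cc(=O)c4c(O)c32)c2cc(C)ccc21` — > 50000 nM
compound 3 `CCN1C(=O)C2(C(C#N)=C(N)Oc3cc4oc(-c5ccc(OC)cc5OC)cc(=O)c4c(O)c32)c2cc(Cl)ccc21` — > 50000 nM

In a functional assay on PC-3 cells (Homo sapiens) for antiproliferative activity, read by MTT assay, with a stated time of 48 h (a higher number here means a weaker inhibitor, a lower number a stronger inhibitor), compound 1 gives > 50000 nM, a limit of the assay and not a number. Compound 2 gives > 50000 nM, again a limit. Compound 3 gives > 50000 nM, likewise a limit; compound 3 thus stands at the limit of > 50000 nM in this assay, at which 3 of the 3 values shown sit, with nothing to rank it against the other two.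

Compound 4 `CCN1C(=O)C2(C(C#N)=C(N)Oc3cc4oc(-c5ccc(OC)cc5OC)cc(=O)c4c(O)c32)c2cc(Br)ccc21` carries bromo in place of chloro on an aromatic carbon. Among the measured compounds shown here, no step between measured compounds is available for this change, so no size beyond the scatter is expected in this assay in either direction. Compound 4 is expected to return 60000 nM, with a range of 20000 nM to 200000 nM, most likely again as a limit. The estimated step is a step that the limit leaves unreadable from compound 3 to compound 4, within the scatter.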

Compound 4, half-maximal inhibitory concentration: > 50000 nM
Compound 4 gave a limit, no number (the forecaster's own chance of this, stated with the estimate: 85%); the middle value is on the limit's open side.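

Bromo in place of chloro gives no readable step between compound 3 and compound 4, since both results are limits and not numbers: the limit of > 50000 nM in this assay, at which 4 of the 4 values shown sit.

The compounds shown leave open what any change on the shared core does in this assay, as none of them gives a number there.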